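Cyclohexylamino to 4-methylpiperidin-1-yl on the shared core

The source may hold more compounds than are shown below. What is called first, only, known or untested is meant among the compounds shown, and "the series" means these compounds.

Compound 1 `Nc1ccccc1NC(=O)/C=C/c1ccc(Cn2cnc3c(NC4CCCCC4)nc(Cl)nc32)cc1` is the weakest of the three measured compounds in a functional assay on NCI-H460 cells (Homo sapiens) for antiproliferative activity, read by CCK-8 assay, with a stated time of 72 h, tested at 8 uM (a lower number here means a weaker effect, a higher number a stronger effect of the compound at the concentration tested), where compound 1 gives 24.9%. Compound 2 `CCCCn1cnc2c(Nc3cccc(Cl)c3)nc(NCOCc3ccc(/C=C/C(=O)Nc4ccccc4N)cc3)nc21` gives 51.1% in this assay, and compound 3 `CC(C)n1cnc2c(NCc3ccc(C(=O)Nc4ccccc4N)cc3)nc(Cl)nc21` gives 80.5%; both gaps to compound 1 lie beyond the scatter. Compound 4 `CC1CCN(c2nc(Cl)nc3c2ncn3Cc2ccc(/C=C/C(=O)Nc3ccccc3N)cc2)CC1` has not been measured. It shares every atom with compound 1 but joins them differently: 4-methylpiperidin-1-yl in place of cyclohexylamino on an aromatic carbon. The ring that enters carries no hydrogen-bond donor, whereas the one that leaves had one. Among the compounds with values here, no measured pair isolates this change, so no measured step guides the expectation. In this assay the estimated step is a number 0.1 percentage points higher from compound 1 to compound 4 (within the scatter), not beyond the scatter in either direction. Compound 4 is therefore expected to give about 25%, within a range from 5% to 55%.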

Compound 4, a percentage reported as inhibition, at one concentration (the size of the read-out at that concentration, not a potency): 10.8%
The estimate for compound 4 lay 14.2 percentage points above the measured number, within the range that was stated.
By their numbers in this assay, from the lowest: compound 4; then compound 1; then compound 2; then compound 3.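

In this assay, within the data shown here, the exchange of cyclohexylamino for 4-methylpiperidin-1-yl gives the first measured step at this position, a number 14.1 percentage points lower from compound 1 to compound 4 (beyond the scatter). This shows that the number responds to a rearrangement of the same atoms on this aromatic carbon, with the other parts of compound 1 unchanged. The entering ring has no hydrogen-bond donor, but nothing measured here explains the step. The compounds shown leave open whether the lost donor or the ring's methyl group accounts for the drop. Piperidin-1-yl and cyclohexyl(methyl)amino at this carbon would separate these two changes.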